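From compound 2 to compound 3: adding benzyloxy

This account rests on a few compounds, and the source may have more. Where it says the series, first, only, none or still open, it means among the compounds named here.

In a functional assay on A549 cells (Homo sapiens) for cytotoxicity, read by colorimetric assay and MTT assay (on this read-out higher numbers stand for weaker inhibition and lower numbers for stronger inhibition), compound 1 (`COc1ccc2cc(-c3ccccc3)c(O)nc2c1`) gives 10000 nM as its reading, and compound 2 (`COc1cc(OC)c2cc(-c3ccccc3)c(O)nc2c1`) gives 10000 nM as its reading, so compound 2 stands level with compound 1 at the digits shown.

The next structure is compound 3 (`COc1cc(OC)c2cc(-c3ccc(OCc4ccccc4)cc3)c(O)nc2c1`), which carries benzyloxy in place of hydrogen on an aromatic carbon of a six-membered aromatic ring of carbon only, para to a large group (benzyloxy in place of hydrogen on an aromatic carbon).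

Among the measured compounds shown here, only one measured step bears on this change. That step, no change at the digits printed from compound 1 to compound 2 (within the scatter) for methoxy in place of hydrogen on an aromatic carbon, is a weak guide. For the measured compounds named here, it involves a different and smaller group, and no measured compound carries benzyloxy, so the data give no direct size for this change.

The expected step is a 1.7-fold lower number from compound 2 to compound 3 (0.22 log units; within the scatter) in this assay and leans only slightly toward lower numbers, with wide uncertainty in either direction. Compound 3 is expected near 6000 nM (expected range 1500 nM to 15000 nM).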

Compound 3, half-maximal inhibitory concentration: 10000 nM
Compound 3: the middle estimate sits 1.7-fold (0.22 log units) below what was measured; the range from low to high includes it.
By their numbers in this assay, from the lowest: compounds 1, 2 and 3 (each within the scatter of the next).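

In this assay, putting benzyloxy on this aromatic carbon gives no change at the digits printed from compound 2 to compound 3 (within the scatter). Among the compounds shown here, this is the first reading for a substituent on this six-membered aromatic ring of carbon only, para to a large group, and the only earlier step, no change at the digits printed from compound 1 to compound 2 (within the scatter), concerned methoxy elsewhere on the shared core. The reading of compound 3, 10000 nM, therefore shows that adding a group of this size here, with its own aromatic ring, leaves the printed value unchanged from that of compound 2, and nothing at hand accounts for that outcome.

On these data alone, whether a smaller group at the same place, such as methoxy or fluorine, or a different one, such as an amine, a carboxylic acid or a longer alkyl chain, would change the reading remains open. Also open, as far as these compounds go, is whether replacing the hydroxyl group on the shared core with an amine or a methoxy group would move the series away from the value shared by these compounds.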